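A few compounds are considered here, and "the series" means these few. Any claim that something is new, unique, unknown or untested is made for them only; others in the source may bear on it.

Working notes on the series. In a functional assay on MCF7 cells (Homo sapiens) for inhibition, read by MTT assay, with a stated time of 72 h, tested at 50 uM (a higher number here means more inhibition of growth at the concentration tested, a lower number less inhibition of growth), compound 1 `C=CCc1cc(O)c(O)c(CN2CCC(CCO)CC2)c1` gives 33.3% and compound 2 `C=CCc1ccc(OCc2cn(-c3ccc(C#N)cc3)nn2)c(O)c1` gives 35.6% on the same read-out. These two numbers lie within the usual scatter of each other, so compound 2 cannot be separated from compound 1 on the data so far. The next compound is compound 3 `C=CCc1ccc(OCc2cn(-c3ccc(Br)cc3)nn2)c(O)c1`, which has bromo in place of cyano on an aromatic carbon, para to a large group, so that 4-cyanophenyl becomes 4-bromophenyl bromo in place of cyano on an aromatic carbon with the rest of compound 2 kept. Going by the values given here, no measured step covers this change, so the data offer no direct guide. In this assay the expected move is small and upward, an estimated a number 1.4 percentage points higher from compound 2 to compound 3 (within the scatter) that stays within the scatter. Compound 3 is estimated at 37% within an expected range of 22% to 52% in this measurement.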

Compound 3, percent growth inhibition at one concentration: 29.1%
Compound 3: the middle estimate sits 7.9 percentage points above what was measured; measured number inside the range.
By their numbers in this assay, from the lowest: compounds 3, 1 and 2 (each within the scatter of the next).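

In this assay, going by these compounds alone, bromo in place of cyano on an aromatic carbon, para to a large group, gives a number 6.5 percentage points lower from compound 2 to compound 3 (within the scatter), the first measured step at this position. On this read-out, the 4-cyanophenyl and 4-bromophenyl groups cannot be told apart, even though the nitrile with its triple bond and hydrogen-bond acceptor gives way to a single bromine atom with neither. No measurement at hand bears on the reason for this result.

From the compounds shown here alone, whether an amino group, a carboxylic acid or a methoxy group at this position would give a step beyond the scatter remains open. Also open, going by these compounds, is whether compound 2 and compound 3 would remain indistinguishable across a range of concentrations, since this assay tests only one.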